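The source may report more compounds than this note shows. Statements on the series, on what has been measured and on what is new or still open speak of the compounds shown alone.

compound 1 `COc1ccc(-c2ncnn2-c2cc(OC)c(OC)c(OC)c2)cc1`: 950 nM
compound 2 `COc1cccc(-c2ncnn2-c2cc(OC)c(OC)c(OC)c2)c1`: > 10000 nM (a limit)
compound 3 `COc1cc(-c2ncnn2-c2ccc(F)cc2)cc(OC)c1OC`: > 10000 nM (a limit)

Within the data shown here, in a functional assay on K562 cells (Homo sapiens) for antiproliferative activity, read by MTT assay, with a stated time of 72 h (a higher number here means a weaker inhibitor, a lower number a stronger inhibitor), compound 1 gives 950 nM, the only true number of the three. Compound 2 reads > 10000 nM, which is a limit of the assay. Compound 3 reads > 10000 nM, also a limit.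

Compound 4 `COc1cc(-n2ncnc2-c2ccc(OC(F)(F)F)cc2)cc(OC)c1OC` differs from compound 1 in one place, methoxy to trifluoromethoxy: trifluoromethyl in place of methyl on an oxygen on an aromatic ring.

The nearest measured evidence is an at least 10-fold higher number from compound 1 to compound 2 (1.02 log units; beyond the scatter), with 3-methoxyphenyl in place of 4-methoxyphenyl. That step is large but is a different change, so it shows only that potency can fall steeply when this group is altered.

A moderate weakening is therefore expected, a 3.2-fold higher number from compound 1 to compound 4 (0.50 log units; beyond the scatter). For compound 4 the estimated value is 3000 nM, with an expected range of 700 nM to 10000 nM.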

Compound 4, half-maximal inhibitory concentration: > 10000 nM
Compound 4: a limit, no number; the forecaster's own chance of this, stated with the estimate: 30%; middle value at least 3.3-fold (0.52 log units) away from the limit.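

Keeping the oxygen in place and putting trifluoromethyl in place of methyl gives an at least 10-fold higher number from compound 1 to compound 4 (1.02 log units; beyond the scatter) in this assay. Activity here therefore depends on the methoxy group itself as well as on where it sits, as neither change shown keeps the activity of compound 1. The value of compound 4 is a limit, so its step gives only a minimum size, because readings stop there: the limit of > 10000 nM in this assay, at which 3 of the 4 values shown sit.

Going by these compounds, whether an ethoxy, a hydroxyl or an amine at this place would keep any activity stays open. On these data alone, how far compound 4 lies past its limit also stays open.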